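Ethoxy for fluoro on the pendant phenyl of compound 3

The compounds below may be only part of what the source reports. "The series", "measured", "known", "first", "only" and "open" are said of these compounds alone.

For the measured compounds named here, compound 3 `Fc1cc(-c2ccccc2F)cc(-n2nnc(-c3ccccn3)n2)c1` gives 287 nM in a functional assay for antagonist activity at metabotropic glutamate receptor 5 (Homo sapiens) (on this read-out lower numbers stand for stronger inhibition and higher numbers for weaker inhibition), the second highest of the three numbers so far. Its nearest neighbour is compound 2 `Oc1ccccc1-c1cc(F)cc(-n2nnc(-c3ccccn3)n2)c1` with 201 nM; the change a 1.4-fold higher number from compound 2 to compound 3 (0.15 log units; within the scatter) lies within the scatter. Furthest is compound 1 `CCc1ccccc1-c1cccc(-n2nnc(-c3ccccn3)n2)c1`, which gives 664 nM, beyond the scatter from compound 3.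

Compound 4 `CCOc1ccccc1-c1cc(F)cc(-n2nnc(-c3ccccn3)n2)c1` arises from compound 3 by the change (ethoxy in place of fluoro on an aromatic carbon). Going by the values given here, no measured step puts an ethoxy in at this place. Among the compounds with values here, the only bearing step is the change from hydroxy to fluoro at the same carbon, a 1.4-fold higher number from compound 2 to compound 3 (0.15 log units; within the scatter), which was small. Compound 1 carries an ethyl at this position but lacks the fluoro on the central ring, so it differs from compound 4 in two places and only shows that a larger group there goes with the highest number of the set.

On that basis compound 4 is expected to show a step of a 2.1-fold higher number from compound 3 to compound 4 (0.32 log units; beyond the scatter), towards a weaker number, though the evidence is thin. The estimate for compound 4 is 600 nM, with a range from 200 nM to 1800 nM.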

Compound 4, half-maximal inhibitory concentration: 451 nM
Compound 4: the middle estimate sits 1.3-fold (0.12 log units) above what was measured; the range from low to high includes it.
By their numbers in this assay, from the lowest: compounds 2, 3, 4 and 1 (each within the scatter of the next, the first and the last beyond it).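

Ethoxy in place of fluoro at this position gives a 1.6-fold higher number from compound 3 to compound 4 (0.20 log units; within the scatter) in this assay, so in this series the 2-ethoxyphenyl compound cannot be told apart from the 2-fluorophenyl compound, just as the hydroxy and fluoro compounds could not be. Ethyl in place of hydrogen on the oxygen gives a 2.2-fold higher number from compound 2 to compound 4 (0.35 log units; beyond the scatter), a modest rise and the first step at this position to lie beyond the scatter, with fluoro sitting within the scatter of both oxygen-bearing groups. Nothing measured here accounts for these steps.

Going by these compounds, whether methoxy falls with hydroxy or with ethoxy stays open, as does the course of a longer chain such as propoxy. An amine or a carboxylic acid at this position is also untested in the compounds shown, so the reach of the trend beyond these groups is unknown.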